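Moving the bromine on a bromophenyl group

A few compounds are considered here, and "the series" means these few. Any claim that something is new, unique, unknown or untested is made for them only; others in the source may bear on it.

Measured so far in a functional assay on MCF7 cells (Homo sapiens) for cytotoxicity, read by MTT assay, with a stated time of 72 h; a higher number here means a weaker inhibitor, a lower number a stronger inhibitor
compound 1 `COc1ccc(/C=C2\CCC/C(=C\c3ccccc3Cl)C2=O)cc1OC` gives 10400 nM
compound 2 `COc1ccc(/C=C2\CCC/C(=C\c3ccccc3Br)C2=O)cc1OC` gives 9500 nM
Not yet measured
compound 3 `COc1ccc(/C=C2\CCC/C(=C\c3cccc(Br)c3)C2=O)cc1OC`

Among the measured compounds shown here, compound 2 gives 9500 nM and stands level with the only other measured compound. The next change is 3-bromophenyl in place of 2-bromophenyl on a double-bonded chain carbon bound to a double-bonded ring carbon and it puts 3-bromophenyl in place of 2-bromophenyl. For the measured compounds named here, the one measured step is a 1.1-fold lower number from compound 1 to compound 2 (0.04 log units; within the scatter) and it swaps chloro for bromo rather than moving a group, so it bears only loosely on this change. Going by the values given here, no measured step shows what moving the bromine does. The step expected is a 1.1-fold lower number from compound 2 to compound 3 (0.02 log units; within the scatter) and so no change beyond the scatter is anticipated, in either direction. Compound 3 is expected to give 9000 nM in this assay with 4000 nM to 20000 nM as its estimated range.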

Compound 3, half-maximal inhibitory concentration: 5300 nM
For compound 3 the middle estimate is 1.7-fold (0.23 log units) above the measured one; the range from low to high includes it.
By their numbers in this assay, from the lowest: compounds 3, 2 and 1 (each within the scatter of the next).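

Among the compounds shown here, compounds 1 and 2 differ only in the halogen, so compound 3 gives the first reading on moving the bromine: in this assay, 3-bromophenyl in place of 2-bromophenyl gives a 1.8-fold lower number from compound 2 to compound 3 (0.25 log units; within the scatter). Changing both the halogen and its place, 3-bromophenyl in place of 2-chlorophenyl, gives a 2.0-fold lower number from compound 1 to compound 3 (0.29 log units; within the scatter), so neither step goes beyond the scatter. Nothing available explains these numbers.

Still open, from the compounds shown here alone, is whether an amine or a carboxylic acid in place of the bromine would give a step beyond the scatter.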